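Aryl variation on the piperazine nitrogen in a T-type blocker series

A few compounds are considered here, and "the series" means these few. Any claim that something is new, unique, unknown or untested is made for them only; others in the source may bear on it.

Measured so far:
compound 1 `CCCc1nc(-c2ccccc2)c(CNCCCN2CCN(c3cccc(C(F)(F)F)c3)CC2)o1` — 650 nM
compound 2 `CCCc1nc(-c2ccccc2)c(CNCCCN2CCN(c3ccc(Cl)cc3)CC2)o1` — 1310 nM

Among the measured compounds shown here, in an assay on HEK293 cells for inhibition of Voltage-dependent T-type calcium channel subunit alpha-1G (Homo sapiens), read by patch clamp (a lower number here means a stronger inhibitor, a higher number a weaker inhibitor), compound 2 gives 1310 nM, the highest of the two numbers so far; its nearest neighbour is compound 1 at 650 nM, and the step of a 2.0-fold higher number from compound 1 to compound 2 (0.30 log units; within the scatter) lies within the scatter. Both compounds share the same core and differ only in the aryl group on the ring nitrogen.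

Compound 3 `CCCc1nc(-c2ccccc2)c(CNCCCN2CCN(c3ccc(C)c(C)c3)CC2)o1` is not yet measured. It differs from compound 2 by 3,4-dimethylphenyl in place of 4-chlorophenyl on an amine nitrogen in a ring. For the measured compounds named here, the only measured step that bears on this position is a 2.0-fold higher number from compound 1 to compound 2 (0.30 log units; within the scatter), an aryl-for-aryl exchange that stayed within the scatter. Going by the values given here, no step in the data speaks to a methyl-for-halogen exchange. On this basis compound 3 is expected to show no step beyond the scatter in this assay, the expected step being a 1.1-fold lower number from compound 2 to compound 3 (0.04 log units; within the scatter). The estimate for compound 3 is 1200 nM, with a range of 400 nM to 3600 nM.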

Compound 3, half-maximal inhibitory concentration: 3020 nM
Estimate against measurement, compound 3: 2.5-fold (0.40 log units) below, and the stated range covers the measured number.
By their numbers in this assay, from the lowest: compounds 1 and 2 (each within the scatter of the next); then compound 3.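

In this assay, the aryl group on the amine nitrogen in a ring now gives steps beyond the scatter: 3,4-dimethylphenyl in place of 4-chlorophenyl gives a 2.3-fold higher number from compound 2 to compound 3 (0.36 log units; beyond the scatter), and 3,4-dimethylphenyl in place of 3-(trifluoromethyl)phenyl gives a 4.6-fold higher number from compound 1 to compound 3 (0.67 log units; beyond the scatter). The position therefore does respond to the choice of aryl group, although compound 1 and compound 2 remain within the scatter of each other. No measurement shown accounts for this shift.

On these data alone, it remains open whether one methyl group on the phenyl ring would give a similar number, and how a methoxy group, a nitrile or an unsubstituted phenyl would compare at this position. These compounds also leave open how the number responds to changes elsewhere on the shared core.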